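Notes: 2-(methylcarbamoyl)ethynyl in place of 2-(methylcarbamoyl)ethenyl

The source may hold more compounds than are shown below. What is called first, only, known or untested is meant among the compounds shown, and "the series" means these compounds.

- compound 1 `CNC(=O)/C=C/c1ccc(NC(=O)Nc2ccc(Cl)c(C(F)(F)F)c2)cc1` gives 11700 nM
- compound 2 `CC1CN(C(=O)/C=C/c2ccc(NC(=O)Nc3ccc(Cl)c(C(F)(F)F)c3)cc2)CC(C)O1` gives 9100 nM

Both values come from a functional assay on HT-29 cells (Homo sapiens) for inhibition, read by MTT assay, with a stated time of 120 h; on this read-out lower numbers stand for stronger inhibition and higher numbers for weaker inhibition. Only these two compounds are measured, and they lie within the scatter of each other, so compound 1 has no separate standing on these numbers. The next structure is compound 3 `CNC(=O)C#Cc1ccc(NC(=O)Nc2ccc(Cl)c(C(F)(F)F)c2)cc1`. The change is 2-(methylcarbamoyl)ethynyl in place of 2-(methylcarbamoyl)ethenyl on an aromatic carbon, on an aromatic carbon of a six-membered aromatic ring of carbon only, para to a large group. Among the compounds with values here, no measured step touches this chain. The only one, a 1.3-fold lower number from compound 1 to compound 2 (0.11 log units; within the scatter), concerns the group on the carbonyl carbon and is a weak guide here. With so little evidence, no shift beyond the scatter is expected in this assay, in either direction. The estimated step is a 1.2-fold lower number from compound 1 to compound 3 (0.07 log units; within the scatter). Compound 3 is expected at 10000 nM, with an estimated range of 3500 nM to 30000 nM.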

Compound 3, half-maximal inhibitory concentration: 14000 nM
Compound 3: the middle estimate sits 1.4-fold (0.15 log units) below what was measured; low and high end bracket the measured number.
By their numbers in this assay, from the lowest: compounds 2, 1 and 3 (each within the scatter of the next).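

In this assay, this place on the aromatic ring, para to a large group, now has its first measured step: 2-(methylcarbamoyl)ethynyl in place of 2-(methylcarbamoyl)ethenyl gives a 1.2-fold higher number from compound 1 to compound 3 (0.08 log units; within the scatter). With the earlier step on the carbonyl carbon, a 1.3-fold lower number from compound 1 to compound 2 (0.11 log units; within the scatter), neither of the two places varied so far shows a shift beyond the scatter. Nothing measured here speaks to why the two chains read alike.

The compounds shown leave open whether a carboxylic acid or a primary amine in place of the methylcarbamoyl end of this chain, or a longer chain at the same place, would give a step beyond the scatter. The rest of the core of compound 1 is shared by all three compounds, so its part in these numbers remains unread.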